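The source may report more compounds than this note shows. Statements on the series, on what has been measured and on what is new or still open speak of the compounds shown alone.

Measured compounds:
compound 1, `COc1cc(/C=C/C(=O)NCc2ccc(OCc3nc(C)c(C)nc3C)c(OC)c2)ccc1OCc1nc(C)c(C)nc1C`, 11100 nM
compound 2, `COc1cccc(/C=C/C(=O)NCc2ccc(O)c(OC)c2)c1`, 5240 nM
compound 3, `COc1cccc(/C=C/C(=O)NCc2ccc(OCc3nc(C)c(C)nc3C)c(OC)c2)c1`, 4320 nM

These three were tested in a functional assay on SH-SY5Y cells (Homo sapiens) for cytotoxicity, read by MTT assay, with stated times of 24 h and 4 h; a lower number here means that less compound is needed, a higher number that more compound is needed for the effect. Compound 3 gives the lowest of the three numbers, but its gap to compound 2, a 1.2-fold lower number from compound 2 to compound 3 (0.08 log units; within the scatter), lies within the scatter, so the two cannot be ordered. Compound 1 stands further off: a 2.6-fold lower number from compound 1 to compound 3 (0.41 log units; beyond the scatter).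

Compound 4, `COc1cc(CNC(=O)/C=C/c2ccc(OC)c(OC)c2OC)ccc1OCc1nc(C)c(C)nc1C`, differs from compound 3 in one place: 2,3,4-trimethoxyphenyl in place of 3-methoxyphenyl on a double-bonded chain carbon bound to a double-bonded chain carbon. Within the data shown here, no measured step changes the substituents of this aryl ring in the same way. Among the measured compounds shown here, the only step that touches this ring at all is a 2.6-fold lower number from compound 1 to compound 3 (0.41 log units; beyond the scatter), where adding a large group there raised the number modestly; the other step, a 1.2-fold lower number from compound 2 to compound 3 (0.08 log units; within the scatter), concerns the opposite end of the molecule and was within the scatter. On that thin basis a small increase is expected for compound 4, a 1.5-fold higher number from compound 3 to compound 4 (0.18 log units; within the scatter), with the step likely near or just beyond the scatter. Compound 4 is therefore estimated at 6500 nM, between 2500 nM and 17000 nM.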

Compound 4, half-maximal effective concentration: 3840 nM
Compound 4: the middle estimate sits 1.7-fold (0.23 log units) above what was measured; low and high end bracket the measured number.
By their numbers in this assay, from the lowest: compounds 4, 3 and 2 (each within the scatter of the next); then compound 1.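

Putting 2,3,4-trimethoxyphenyl in place of 3-methoxyphenyl on a double-bonded chain carbon bound to a double-bonded chain carbon gives a 1.1-fold lower number from compound 3 to compound 4 (0.05 log units; within the scatter) in this assay. Among these compounds, the aryl group here thus grows from 8 to 12 heavy atoms with no readable change in the number, which the earlier compounds could not show: their only step at this ring, a 2.6-fold lower number from compound 1 to compound 3 (0.41 log units; beyond the scatter), concerned a (3,5,6-trimethylpyrazin-2-yl)methoxy group and lies beyond the scatter. No measurement at hand offers an explanation for this result.

The compounds shown leave open how this aryl ring would respond to a hydroxyl group, a chlorine atom or an amine. They also leave open whether 2,3,4-trimethoxyphenyl would behave the same way in the core of compound 2, which carries a free hydroxyl group.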